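The source may hold more compounds than are shown below. What is called first, only, known or untested is meant among the compounds shown, and "the series" means these compounds.

In a functional assay on MCF7 cells (Homo sapiens) for antiproliferative activity, read by MTT assay, with a stated time of 72 h (a lower number here means a stronger inhibitor, a higher number a weaker inhibitor), the three measured compounds gave these numbers:

Compound 1 `COc1cc2c(Oc3ccc(NC(=O)C4(c5nnc(-c6ccc(F)cc6)o5)CC4)cc3F)ccnc2cc1OCCCN1CCCC1`: 310 nM
Compound 2 `COc1cc2c(Oc3ccc(NC(=O)C4(c5nnc(-c6ccc(F)cc6)o5)CC4)cc3F)ccnc2cc1OCCCN1CCN(C)CC1`: 2610 nM
Compound 3 `COc1cc2c(Oc3ccc(NC(=O)C4(c5nnc(-c6ccc(F)cc6)o5)CC4)cc3F)ccnc2cc1OCCCN1CCC(C)CC1`: 740 nM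

Compound 3 holds the second highest of the three numbers; its nearest neighbour is compound 1, as a 2.4-fold higher number from compound 1 to compound 3 (0.38 log units; beyond the scatter) shows, and compound 2 lies further off, as a 3.5-fold lower number from compound 2 to compound 3 (0.55 log units; beyond the scatter) shows. Compound 4 `COc1cc2c(Oc3ccc(NC(=O)C4(c5nnc(-c6ccc(F)cc6)o5)CC4)cc3F)ccnc2cc1OCCCN1CCCCC1` is not yet measured and differs from compound 3 by hydrogen in place of methyl on a saturated ring carbon. Among the compounds with values here, no measured pair removes a methyl from a ring carbon, so the ring swaps a 2.4-fold higher number from compound 1 to compound 3 (0.38 log units; beyond the scatter) and a 3.5-fold lower number from compound 2 to compound 3 (0.55 log units; beyond the scatter) are the only steps that bear on it, and both were modest. A modest move toward the number of compound 1 is therefore expected, a 1.6-fold lower number from compound 3 to compound 4 (0.22 log units; within the scatter). Compound 4 is estimated at 450 nM, within 200 nM to 1100 nM.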

Compound 4, half-maximal inhibitory concentration: 1010 nM
The estimate for compound 4 lay 2.2-fold (0.35 log units) below the measured number; the measured number falls inside the stated range.
By their numbers in this assay, from the lowest: compound 1; then compounds 3 and 4 (each within the scatter of the next); then compound 2.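

Methyl or hydrogen on the saturated ring carbon, three ring bonds from the ring nitrogen, makes no readable difference in this assay, with a 1.4-fold higher number from compound 3 to compound 4 (0.14 log units; within the scatter). The gaps to the other amines also hold without the methyl, with a 3.3-fold higher number from compound 1 to compound 4 (0.51 log units; beyond the scatter) for piperidin-1-yl in place of pyrrolidin-1-yl and a 2.6-fold lower number from compound 2 to compound 4 (0.41 log units; beyond the scatter) for piperidin-1-yl in place of 4-methylpiperazin-1-yl. Nothing available explains these differences. From the compounds shown here alone, whether a hydroxyl or a phenyl group on that ring carbon would also leave the number unmoved remains open. So does where a morpholin-4-yl group would fall among these amines.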